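A few compounds are considered here, and "the series" means these few. Any claim that something is new, unique, unknown or untested is made for them only; others in the source may bear on it.

Compound 1 `c1ccc(-c2nccnc2OC2CN(c3ccc4ccccc4n3)C2)cc1` and compound 2 `N#Cc1ccc(-c2nccnc2OC2CN(c3ccc4ccccc4n3)C2)cc1` share one core and differ only by a cyano in place of hydrogen on an aromatic carbon. In a physicochemical assay for solubility, in phosphate buffer, at pH 7.4 (on this read-out higher numbers stand for higher solubility and lower numbers for lower solubility), compound 1 gives < 1000 nM, which is a limit of the assay rather than a number. In this assay compound 2 likewise gives < 1000 nM, again a limit and not a number. Between the two lies a step that the two limits leave unreadable from compound 1 to compound 2 because of the limit of < 1000 nM in this assay, at which 2 of the 2 values shown sit. Compound 2 therefore stands at that limit, with no number of its own to anchor the next step. Compound 3 `c1ccc2nc(N3CC(Oc4nccnc4-c4cncnc4)C3)ccc2c1` differs from compound 2 by pyrimidin-5-yl in place of 4-cyanophenyl on an aromatic carbon. Among the measured compounds shown here, the only measured step that bears on this change is the one from compound 1 to compound 2, and its size cannot be read, so it gives no direction for compound 3. Compound 3 is expected to show an at least 1.5-fold higher number from compound 2 to compound 3 (0.17 log units; that floor lies within the scatter) in this assay. Compound 3 is estimated at 1500 nM, with a range from 400 nM to 8000 nM.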

Compound 3, solubility: 254000 nM
Compound 3: the middle estimate sits 170-fold (2.23 log units) below what was measured; measured number above the stated range.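

This aromatic carbon, on the six-membered aromatic ring with 2 nitrogen, now gives the first readable steps: in this assay, pyrimidin-5-yl in place of 4-cyanophenyl gives an at least 250-fold higher number from compound 2 to compound 3 (2.40 log units; beyond the scatter), and pyrimidin-5-yl in place of phenyl gives an at least 250-fold higher number from compound 1 to compound 3 (2.40 log units; beyond the scatter). A change at this place can thus come with a large step beyond the scatter, which the earlier, unreadable step from phenyl to 4-cyanophenyl could not show. Both new steps are floors and not full sizes, and only compound 3 has a number of its own: the limit of < 1000 nM in this assay, at which 2 of the 3 values shown sit.

The compounds shown leave open how far the read-out would move with a single ring nitrogen, as in pyridin-3-yl. They also leave open what a non-aromatic amine such as morpholine would give at this place.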